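The compounds below may be only part of what the source reports. "The series", "measured", "known", "first", "only" and "open" are said of these compounds alone.

Compound 1 `O=C(CN1CCCCC1)Nc1ccc(-c2nc3cc(C(F)(F)F)ccc3[nH]2)cc1` gives 6000 nM
Compound 2 `CCN(CC)CC(=O)Nc1ccc(-c2nc3cc(C(F)(F)F)ccc3n2C)cc1` gives 57000 nM
Compound 3 `O=C(CN1CCCCC1)Nc1ccc(-c2nc3cc(Cl)c(Cl)cc3[nH]2)cc1` gives 45000 nM

In an ADME assay on MDBK cells (Bos taurus) for cytotoxicity, read by MTT assay, with a stated time of 96 h (a lower number here means that less compound is tolerated, a higher number that more compound is tolerated), compound 2 stands at the highest of the three numbers. Compound 3 lies within the scatter of compound 2, while compound 1 lies beyond it, at a lower number. Compound 4 `Cn1c(-c2ccc(NC(=O)CN3CCN(c4ccccc4)CC3)cc2)nc2cc(C(F)(F)F)ccc21` has not yet been measured. It differs from compound 2 in one place: 4-phenylpiperazin-1-yl in place of diethylamino on a saturated chain carbon bound to a carbonyl carbon. Within the data shown here, no measured pair shows this change, so its effect is unknown here. The account expects a moderate step in this assay towards a lower number for compound 4, probably beyond the scatter. The estimate for compound 4 is 20000 nM, in a range from 6000 nM to 60000 nM. The step expected is a 2.9-fold lower number from compound 2 to compound 4 (0.45 log units; beyond the scatter).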

Compound 4, half-maximal cytotoxic concentration: 1400 nM
Estimate against measurement, compound 4: 14-fold (1.15 log units) above; the measured number lies below the stated range.
By their numbers in this assay, from the lowest: compound 4; then compound 1; then compounds 3 and 2 (each within the scatter of the next).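

In this assay the swap of diethylamino for 4-phenylpiperazin-1-yl on a saturated chain carbon bound to a carbonyl carbon gives a 41-fold lower number from compound 2 to compound 4 (1.61 log units; beyond the scatter) and is a large step. Among these compounds, this is the first one-place comparison, and it shows that the number is highly sensitive to the group at this position. No available evidence bears on why the step occurs. The compounds shown leave open whether the step follows the six-membered aromatic ring or the non-aromatic ring carrying it. A methyl group in place of that aromatic ring would separate the two.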